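A few compounds are considered here, and "the series" means these few. Any claim that something is new, unique, unknown or untested is made for them only; others in the source may bear on it.

Measured in a functional assay on A549 cells (Homo sapiens) for antiproliferative activity, read by MTT assay, with a stated time of 48 h; on this read-out higher numbers stand for weaker inhibition and lower numbers for stronger inhibition:
- Compound 1 `COc1ccc(/C=C/c2cc(OC)cc(OC)c2/C=C/C(=O)c2cccc(OC)c2)cc1`: 6.1 ug/mL
- Compound 2 `COc1ccc(/C=C/c2cc(OC)cc(OC)c2/C=C/C(=O)c2ccc(F)cc2)cc1`: 6.6 ug/mL
- Compound 3 `COc1ccc(/C=C/c2cc(OC)cc(OC)c2/C=C/C(=O)c2ccc(Cl)cc2)cc1`: 6.4 ug/mL

Compound 3, at 6.4 ug/mL, cannot be told apart from the other two compounds in this assay. The measured gaps are a 1.0-fold higher number from compound 1 to compound 3 (0.02 log units; within the scatter) and a 1.0-fold lower number from compound 2 to compound 3 (0.01 log units; within the scatter).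

Compound 4 `COc1ccc(/C=C/c2cc(OC)cc(OC)c2/C=C/C(=O)c2ccc(-c3ccccc3)cc2)cc1` has phenyl in place of chloro on an aromatic carbon.

Within the data shown here, the steps that bear on this change are those that alter the aryl group on the carbonyl carbon: a 1.1-fold higher number from compound 1 to compound 2 (0.03 log units; within the scatter), along with the two above. All are small and within the scatter, so this position has shown no sensitivity so far. However, none of these steps adds a ring at this position, so they are only a loose guide, and the range must stay wide.

No change beyond the scatter is therefore expected, and the estimated step is a 1.1-fold higher number from compound 3 to compound 4 (0.04 log units; within the scatter). Compound 4 is expected to read 7 ug/mL, with an estimated range from 3.5 ug/mL to 14 ug/mL.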

Compound 4, half-maximal inhibitory concentration: 4.6 ug/mL
The estimate for compound 4 lay 1.5-fold (0.18 log units) above the measured number, and the stated range covers the measured number.
By their numbers in this assay, from the lowest: compounds 4, 1, 3 and 2 (each within the scatter of the next).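

In this assay, among these compounds, the earlier compounds only compared single substituents or a methoxy-bearing ring, whereas here a whole phenyl ring takes the place of one chlorine atom. That larger swap still gives a 1.4-fold lower number from compound 3 to compound 4 (0.14 log units; within the scatter) and the comparisons with the other two compounds give a 1.4-fold lower number from compound 2 to compound 4 (0.16 log units; within the scatter) and a 1.3-fold lower number from compound 1 to compound 4 (0.12 log units; within the scatter) so a second aromatic ring at this position, para to a large group, produces no change that can be told from the scatter. Nothing measured here offers an explanation for this tolerance.

From the compounds shown here alone, whether any group at this position can move the reading beyond the scatter remains open. A basic amine such as a piperazine, a carboxylic acid or a longer alkyl chain could test this, as none of them appears among these compounds.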